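Swapping the pyridine of compound 1 for a dihydropyran

The source may report more compounds than this note shows. Statements on the series, on what has been measured and on what is new or still open speak of the compounds shown alone.

The three measured compounds share one core and differ only in the group on a double-bonded ring carbon. Compound 1 `C[C@@H](O[C@H]1CN2C(=O)C=C(c3ccncc3)CC2[C@@H]1c1ccc(F)cc1)c1cc(C(F)(F)F)cc(C(F)(F)F)c1` carries pyridin-4-yl there and, in an assay on CHO cells for displacement of a labelled ligand from Substance-P receptor (Homo sapiens) (on this read-out higher numbers stand for weaker inhibition and lower numbers for stronger inhibition), compound 1 gives 0.14 nM, the lowest of the three numbers. Compound 2 `Cc1cc(C2=CC(=O)N3C[C@H](O[C@H](C)c4cc(C(F)(F)F)cc(C(F)(F)F)c4)[C@@H](c4ccc(F)cc4)C3C2)ccn1` bears a methyl on that pyridine and gives 0.51 nM; compound 3 `CCc1noc(C2=CC(=O)N3C[C@H](O[C@H](C)c4cc(C(F)(F)F)cc(C(F)(F)F)c4)[C@@H](c4ccc(F)cc4)C3C2)n1` replaces the pyridine with 3-ethyl-1,2,4-oxadiazol-5-yl and gives 0.4 nM. The two steps away from compound 1 are both modest rises: a 3.6-fold higher number from compound 1 to compound 2 (0.56 log units; beyond the scatter) and a 2.9-fold higher number from compound 1 to compound 3 (0.46 log units; beyond the scatter). Compound 2 and compound 3 lie within the scatter of each other, a 1.3-fold lower number from compound 2 to compound 3 (0.11 log units; within the scatter).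

Compound 4 `C[C@@H](O[C@H]1CN2C(=O)C=C(C3=CCOCC3)CC2[C@@H]1c1ccc(F)cc1)c1cc(C(F)(F)F)cc(C(F)(F)F)c1` differs from compound 1 at the same place: a group of 6 heavy atoms (5 carbon, 1 oxygen; one six-membered non-aromatic ring with 1 hetero atom) in place of a group of 6 heavy atoms (5 carbon, 1 nitrogen; one six-membered aromatic ring with 1 hetero atom), on a double-bonded ring carbon The replacement is a six-membered non-aromatic ring with one oxygen in place of the aromatic pyridine. Both measured changes at this position, the methyl of compound 2 and the oxadiazole of compound 3, cost a modest amount, so a modest rise in this assay is expected for compound 4 as well, on the order of a 2.9-fold higher number from compound 1 to compound 4 (0.46 log units; beyond the scatter). The estimate for compound 4 is therefore 0.4 nM, with a range from 0.15 nM to 1.2 nM.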

Compound 4, half-maximal inhibitory concentration: 0.18 nM
Beside the measured number, compound 4's estimate is 2.2-fold (0.35 log units) above it; measured number inside the range.
By their numbers in this assay, from the lowest: compounds 1 and 4 (each within the scatter of the next); then compounds 3 and 2 (each within the scatter of the next).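

Replacing pyridin-4-yl with the six-membered non-aromatic ring of compound 4 gives no change beyond the scatter in this assay (a 1.3-fold higher number from compound 1 to compound 4 (0.11 log units; within the scatter)), so at this double-bonded ring carbon the shown result does not depend on an aromatic ring or on a ring nitrogen. Unlike the methyl of compound 2 and the 3-ethyl-1,2,4-oxadiazol-5-yl of compound 3, this replacement keeps the number level with that of compound 1, and it separates from both of those groups (a 2.2-fold lower number from compound 3 to compound 4 (0.35 log units; beyond the scatter); a 2.8-fold lower number from compound 2 to compound 4 (0.45 log units; beyond the scatter)). Nothing shown here accounts for these differences.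

All four compounds carry a ring at this carbon, so the compounds shown leave open how an open chain such as n-butyl, an amine or a carboxylic acid would read there. They also leave open whether the ring oxygen or the ring double bond of compound 4 matters to the number, which a cyclohexenyl ring, with carbon in place of the oxygen, or a tetrahydropyranyl ring, without the double bond, could separate.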